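Adding a Second Trifluoromethyl to Compound 2

The source may report more compounds than this note shows. Statements on the series, on what has been measured and on what is new or still open speak of the compounds shown alone.

Compound 1 `CC(O)(COc1cccc(S(F)(F)(F)(F)F)c1)C(=O)Nc1cccc(S(F)(F)(F)(F)F)c1` gives 26700 nM
Compound 2 `CC(O)(COc1cccc(C(F)(F)F)c1)C(=O)Nc1cccc(S(F)(F)(F)(F)F)c1` gives 22500 nM

Among the measured compounds shown here, in a functional assay on VCaP cells (Homo sapiens) for antiproliferative activity, read by propidium iodide staining, with a stated time of 96 h (on this read-out lower numbers stand for stronger inhibition and higher numbers for weaker inhibition), compound 2 gives 22500 nM and stands within the scatter of compound 1, its only measured neighbour, so the two cannot be ranked. Compound 3 `CC(O)(COc1cc(C(F)(F)F)cc(C(F)(F)F)c1)C(=O)Nc1cccc(S(F)(F)(F)(F)F)c1` carries trifluoromethyl in place of hydrogen on an aromatic carbon of compound 2 (trifluoromethyl in place of hydrogen on an aromatic carbon). For the measured compounds named here, the only measured step (a 1.2-fold lower number from compound 1 to compound 2 (0.07 log units; within the scatter)) swapped one group for another on an aromatic carbon and stayed within the scatter. Going by the values given here, no measured step adds a group to this ring, so the precedent is indirect. On that evidence a modest change toward a lower number in this assay is expected, and the estimated step is a 1.5-fold lower number from compound 2 to compound 3 (0.18 log units; within the scatter) with wide uncertainty. Compound 3 is expected at 15000 nM within an estimated range from 6000 nM to 35000 nM in this measurement.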

Compound 3, half-maximal inhibitory concentration: 2800 nM
Compound 3: the middle estimate sits 5.4-fold (0.73 log units) above what was measured, and the stated range ends above it.
By their numbers in this assay, from the lowest: compound 3; then compounds 2 and 1 (each within the scatter of the next).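

In this assay, adding the second trifluoromethyl gives an 8.0-fold lower number from compound 2 to compound 3 (0.91 log units; beyond the scatter), the only step among these compounds that lies beyond the scatter. The earlier exchange of one group for another on an aromatic carbon, a 1.2-fold lower number from compound 1 to compound 2 (0.07 log units; within the scatter), did not separate its two compounds, whereas replacing hydrogen on this ring, at the carbon meta to a large group and meta to a trifluoromethyl group, does separate compound 3 from compound 2. Nothing measured here bears on why the number falls at this position.

The compounds shown leave open whether the step belongs to trifluoromethyl itself or whether a nitrile, a chlorine or a methyl at this place would give a similar number. They also leave open how a single fluorine or a methoxy group would compare on this ring.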